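Trimming the side chain between compound 1 and compound 4

The source may hold more compounds than are shown below. What is called first, only, known or untested is meant among the compounds shown, and "the series" means these compounds.

Of the compounds shown here, three of one family have been measured in a functional assay on HepG2 cells (Homo sapiens) for antiproliferative activity, read by CCK-8 assay, with a stated time of 72 h, tested at 2 uM; a lower number here means a weaker effect, a higher number a stronger effect of the compound at the concentration tested. Compound 1 `COC(CCn1cnc2c(NCc3ccc(C(=O)Nc4ccccc4N)cc3)nc(Cl)nc21)OC` gives 8.52% in this assay. Compound 2 `CC(C)n1cnc2c(Nc3ccccc3)nc(NCOCc3ccc(C(=O)Nc4ccccc4N)cc3)nc21` gives 6.58%, a number that lies within the usual scatter of compound 1, so the two cannot be told apart. Compound 3 `Cc1ccc(Nc2nc(Cl)nc3c2ncn3Cc2ccc(C(=O)Nc3ccccc3N)cc2)cc1` gives 76.2%, far above compound 1 and beyond the scatter. On these numbers compound 1 stands second highest of three, close to compound 2 and far below compound 3.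

Compound 4 `CCCn1cnc2c(NCc3ccc(C(=O)Nc4ccccc4N)cc3)nc(Cl)nc21` has not yet been measured. It differs from compound 1 in a single place: methyl in place of dimethoxymethyl on a saturated chain carbon, two bonds along the chain from an aromatic nitrogen. The shared core and the amide-bearing arm are untouched. Among the compounds with values here, no measured pair isolates a change of a chain alone, so only a small step is expected, a number 3.5 percentage points higher from compound 1 to compound 4 (within the scatter), with no clear direction beyond the scatter. Compound 4 is therefore estimated to give 12% in this assay, within a range from 0% to 35%.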

Compound 4, a percentage reported as inhibition, at one concentration (the size of the read-out at that concentration, not a potency): 12.4%
For compound 4 the middle estimate is 0.4 percentage points below the measured one; the measured number falls inside the stated range.
By their numbers in this assay, from the lowest: compounds 2, 1 and 4 (each within the scatter of the next); then compound 3.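

Replacing dimethoxymethyl with methyl turns the 3,3-dimethoxypropyl chain into a propyl chain, and the result in this assay is a number 3.9 percentage points higher from compound 1 to compound 4 (within the scatter), so compound 1 and compound 4 cannot be told apart. This is the first pair shown that differs only in this chain, and it indicates that removing the two oxygen atoms and the extra carbon atoms of this group produces no difference beyond the scatter at the concentration tested. Nothing measured here explains why the two compounds read alike.

As far as these compounds go, it remains open whether an amine, a carboxylic acid or a longer chain at this place would give a different number. From the compounds shown here alone, it is also open whether compound 1 and compound 4 would still read alike at another concentration.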